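Hydroxy for Bromo in a Paw-Edema Series

A few compounds are considered here, and "the series" means these few. Any claim that something is new, unique, unknown or untested is made for them only; others in the source may bear on it.

Measured compounds:
compound 1, `Cc1ccc(-c2cc3c(n2-c2ccc(O)c(C(=O)O)c2)CCCC3)cc1`: 30%
compound 2, `O=C(O)c1cc(-n2c(-c3ccc(Br)cc3)cc3c2CCCC3)ccc1O`: 40%

In a functional assay on the whole organism (strain Wistar) for inhibition, with Rattus norvegicus as the target, read by paw edema, with stated times of 30 min and 3 h, at a dose of 200 mg/kg by the oral route (a higher number here means more inhibition at the dose given (going by the name of the read-out), a lower number less inhibition), compound 2 gives 40% and stands highest of the two numbers, though its nearest neighbour, compound 1, lies within the scatter of it, as the step of a number 10 percentage points higher from compound 1 to compound 2 (within the scatter) shows. That single step, bromo in place of methyl on an aromatic carbon, is the only measured one and did not move the read-out beyond the scatter.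

Compound 3, `O=C(O)c1cc(-n2c(-c3ccc(O)cc3)cc3c2CCCC3)ccc1O`, differs from compound 2 by hydroxy in place of bromo on an aromatic carbon. Going by the values given here, no measured step involves a hydroxy group, so the only guide is that the one change at this aromatic carbon was within the scatter. Compound 3 is therefore expected to show a step of no change at the digits printed from compound 2 to compound 3 (within the scatter), that is, none beyond the scatter. Compound 3 is estimated at 40%, within a range of 20% to 60%.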

Compound 3, a percentage reported as inhibition, in the whole organism at one dose (the size of the read-out at that dose, not a potency): 20%
Compound 3: the middle estimate sits 20 percentage points above what was measured; the range from low to high includes it.
By their numbers in this assay, from the lowest: compounds 3, 1 and 2 (each within the scatter of the next, the first and the last beyond it).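

At this aromatic carbon, para to a large group, the choice of group now registers in this assay: going from 4-bromophenyl to 4-hydroxyphenyl gives a number 20 percentage points lower from compound 2 to compound 3 (beyond the scatter), whereas the earlier change of methyl to bromo had stayed within the scatter. Hydroxy in place of methyl gives a number 10 percentage points lower from compound 1 to compound 3 (within the scatter), so of the three groups only bromo and hydroxy stand clearly apart, and methyl cannot be separated from either. No measurement at hand offers an explanation for this result.

The compounds shown leave open whether the step reflects the arrival of hydroxy or the loss of bromo, and whether a methoxy group or an amine at this carbon would read like hydroxy or like bromo. From the compounds shown here alone, it also remains open whether the same change would read alike at another dose.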